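Adding Ethyl to the Phenyl Sulfonamide of Compound 3

The source may report more compounds than this note shows. Statements on the series, on what has been measured and on what is new or still open speak of the compounds shown alone.

Measured in a functional assay on HT-29 cells (Homo sapiens) for antiproliferative activity, read by sulforhodamine B assay, with a stated time of 48 h; on this read-out lower numbers stand for stronger inhibition and higher numbers for weaker inhibition:
- compound 1 `Cc1cccc(NS(=O)(=O)c2ccc(N3CCNC3=O)cc2)c1`: 110 nM
- compound 2 `CCc1ccc(NS(=O)(=O)c2ccc(N3CCNC3=O)cc2)cc1`: 660 nM
- compound 3 `O=C1NCCN1c1ccc(S(=O)(=O)Nc2ccccc2)cc1`: 280 nM

Compound 3 gives the second highest of the three numbers, with compound 2 higher and compound 1 lower. Compound 4 `CCc1cccc(NS(=O)(=O)c2ccc(N3CCNC3=O)cc2)c1` carries ethyl in place of hydrogen on an aromatic carbon, meta to a large group (ethyl in place of hydrogen on an aromatic carbon). Among the measured compounds shown here, two measured steps bear on this change. Compound 1 has methyl in that place, and hydrogen in place of methyl gave a 2.5-fold higher number from compound 1 to compound 3 (0.41 log units; beyond the scatter). Compound 2 has its ethyl elsewhere, and hydrogen in place of ethyl gave a 2.4-fold lower number from compound 2 to compound 3 (0.37 log units; beyond the scatter). Compound 1 is the closer guide, so a modest move to a lower number is expected in this assay, a 2.2-fold lower number from compound 3 to compound 4 (0.33 log units; beyond the scatter). Compound 4 is estimated at 130 nM, with an expected range of 50 nM to 350 nM.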

Compound 4, half-maximal inhibitory concentration: 110 nM
Compound 4: middle estimate off by 1.2-fold (0.07 log units), on the high side; the measured number falls inside the stated range.
By their numbers in this assay, from the lowest: compounds 1 and 4 (each within the scatter of the next); then compound 3; then compound 2.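

Ethyl at this place gives a 2.5-fold lower number from compound 3 to compound 4 (0.41 log units; beyond the scatter) and so matches the move seen with methyl, while no change at the digits printed from compound 1 to compound 4 (within the scatter) shows that the methyl and ethyl groups cannot be told apart here. The place of the ethyl counts, since 3-ethylphenyl in place of 4-ethylphenyl gives a 6.0-fold lower number from compound 2 to compound 4 (0.78 log units; beyond the scatter) in this small set. Nothing measured here accounts for these steps. On these data alone, whether a longer chain, a methoxy group or an amine at this place would hold the lower number remains open.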